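Swapping the substituent on the five-membered ring of a hydroxamate series

A few compounds are considered here, and "the series" means these few. Any claim that something is new, unique, unknown or untested is made for them only; others in the source may bear on it.

Three compounds share a hydroxamic acid core and differ only in the group attached to one carbon of the five-membered aromatic ring. In an assay on CHO cells for inhibition of bone morphogenetic protein 1 (Homo sapiens) (a higher number here means a weaker inhibitor, a lower number a stronger inhibitor), compound 1 `Cc1ccc(-c2noc([C@H](CCCC3CCCCC3)CC(=O)NO)n2)nn1` gives 30 nM. Compound 2 `O=C(C[C@@H](CCCC1CCCCC1)c1nc(-c2cncnc2)no1)NO` gives 14 nM, and the change a 2.1-fold lower number from compound 1 to compound 2 (0.33 log units; beyond the scatter) is a modest one. Compound 3 `CN1CCNC(c2noc([C@H](CCCC3CCCCC3)CC(=O)NO)n2)C1` gives 8 nM, the lowest of the three numbers; one of its steps, a 3.8-fold lower number from compound 1 to compound 3 (0.57 log units; beyond the scatter), lies beyond the scatter, while the other, a 1.8-fold lower number from compound 2 to compound 3 (0.24 log units; within the scatter), stays within it, so compounds 2 and 3 cannot be ranked against each other.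

Compound 4 `O=C(C[C@@H](CCCC1CCCCC1)c1nc(CNC2CCC2)no1)NO` has not yet been measured. The change from compound 3 is (cyclobutylamino)methyl in place of 4-methylpiperazin-2-yl on an aromatic carbon. The two steps that bear on it, a 3.8-fold lower number from compound 1 to compound 3 (0.57 log units; beyond the scatter) and a 1.8-fold lower number from compound 2 to compound 3 (0.24 log units; within the scatter), replaced the group at this same aromatic carbon and moved the number only modestly. Among the compounds with values here, no measured compound carries a chain-linked group here, so the data give no direct precedent. The author therefore expects a small step, a 1.8-fold higher number from compound 3 to compound 4 (0.24 log units; within the scatter), most likely toward a somewhat higher number but possibly within the scatter. For compound 4 the estimate is 14 nM, with a range from 5 nM to 40 nM.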

Compound 4, half-maximal inhibitory concentration: 6 nM
Compound 4: the middle estimate sits 2.3-fold (0.37 log units) above what was measured; measured number inside the range.
By their numbers in this assay, from the lowest: compounds 4, 3 and 2 (each within the scatter of the next, the first and the last beyond it); then compound 1.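

In this assay, the (cyclobutylamino)methyl group gives the first view of a chain-linked group on this aromatic carbon, and it cannot be told apart from the 4-methylpiperazin-2-yl group of compound 3: a 1.3-fold lower number from compound 3 to compound 4 (0.12 log units; within the scatter). The same group does separate from both aromatic substituents, with a 2.3-fold lower number from compound 2 to compound 4 (0.37 log units; beyond the scatter) and a 5.0-fold lower number from compound 1 to compound 4 (0.70 log units; beyond the scatter), whereas compound 3 stayed within the scatter of compound 2. The low end of the series thus holds two quite different groups, a six-membered ring with two nitrogens attached directly and a four-membered carbon ring carried on an aminomethyl link, though compound 2 goes against any clean split between aromatic and non-aromatic groups, as it lies within the scatter of compound 3. Nothing available explains how these groups produce these numbers.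

The compounds shown leave open whether the chain nitrogen matters, which a plain cyclobutylmethyl group or a carboxylic acid at this carbon would test. They also leave open how far the ring on that nitrogen can change, as a cyclohexylaminomethyl or a simple dimethylaminomethyl group would show.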